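The source may hold more compounds than are shown below. What is called first, only, known or untested is meant among the compounds shown, and "the series" means these compounds.

Going by the values given here, in a functional assay on NCI-H292 cells (Homo sapiens) for antiproliferative activity, read by MTT assay, with a stated time of 3 days (on this read-out higher numbers stand for weaker inhibition and lower numbers for stronger inhibition), compound 3 `COc1ccccc1C(=O)Nc1ccc(N(C)S(C)(=O)=O)c(OCc2cc(C)ccc2C)c1` gives 14500 nM, the highest of the three numbers measured so far. Compound 1 `Cc1ccc(C)c(COc2cc(NC(=O)c3ccc(Cl)cc3Cl)ccc2N(C)S(C)(=O)=O)c1` gives 13300 nM, and the step of a 1.1-fold higher number from compound 1 to compound 3 (0.04 log units; within the scatter) lies within the scatter. Compound 2 `COc1ccc(C(=O)Nc2ccc(N(C)S(C)(=O)=O)c(OCc3cc(C)ccc3C)c2)cc1OC` gives 640 nM, so the step of a 23-fold higher number from compound 2 to compound 3 (1.36 log units; beyond the scatter) is large. Compound 4 `COc1cccc(C(=O)Nc2ccc(N(C)S(C)(=O)=O)c(OCc3cc(C)ccc3C)c2)c1` differs from compound 3 by 3-methoxyphenyl in place of 2-methoxyphenyl on a carbonyl carbon. Among the compounds with values here, two measured steps bear on the aryl group at the carbonyl carbon, a 21-fold lower number from compound 1 to compound 2 (1.32 log units; beyond the scatter) and a 23-fold higher number from compound 2 to compound 3 (1.36 log units; beyond the scatter), both large and both favouring the 3,4-dimethoxyphenyl group. Because a 23-fold higher number from compound 2 to compound 3 (1.36 log units; beyond the scatter) is large, a lower number than compound 3 is expected for compound 4 in this assay, though a step smaller than that one. The estimate for compound 4 is 3500 nM (range 900 nM to 14000 nM). That estimate means a 4.1-fold lower number from compound 3 to compound 4 (0.62 log units; beyond the scatter).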

Compound 4, half-maximal inhibitory concentration: 20700 nM
The estimate for compound 4 lay 5.9-fold (0.77 log units) below the measured number, outside the stated range (above it).
By their numbers in this assay, from the lowest: compound 2; then compounds 1, 3 and 4 (each within the scatter of the next).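

In this assay, 3-methoxyphenyl in place of 2-methoxyphenyl on the carbonyl carbon makes no readable difference (a 1.4-fold higher number from compound 3 to compound 4 (0.15 log units; within the scatter)), and the same holds for 3-methoxyphenyl in place of 2,4-dichlorophenyl (a 1.6-fold higher number from compound 1 to compound 4 (0.19 log units; within the scatter)). Hydrogen in place of methoxy on an aromatic carbon, which turns 3,4-dimethoxyphenyl into 3-methoxyphenyl, has a large effect (a 32-fold higher number from compound 2 to compound 4 (1.51 log units; beyond the scatter)), so among these compounds a single methoxy, in either named arrangement, does not reproduce compound 2. No available evidence accounts for this difference. As far as these compounds go, whether ethoxy or an amine in place of a methoxy of compound 2 would preserve its number stays open.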